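Chromanone ethers: the step from compound 3 to compound 4

The source may hold more compounds than are shown below. What is called first, only, known or untested is meant among the compounds shown, and "the series" means these compounds.

Measured compounds:
compound 1, `O=C1CC(c2ccccc2OCc2ccc(F)cc2)Oc2ccccc21`, 25500 nM
compound 2, `CC(C)c1ccc(COc2ccccc2C2CC(=O)c3ccccc3O2)cc1`, 28600 nM
compound 3, `CC(C)=CCOc1ccccc1C1CC(=O)c2ccccc2O1`, 34300 nM

In a functional assay on J774.A1 cells (Mus musculus) for inhibition, read by Griess assay, with stated times of 1 h and 24 h (on this read-out lower numbers stand for stronger inhibition and higher numbers for weaker inhibition), compound 3 gives the highest of the three numbers, yet its nearest neighbour is compound 2 at 28600 nM and its furthest is compound 1 at 25500 nM, and both gaps sit within the scatter, so no order among the three can be read.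

Compound 4, `O=C1CC(c2ccccc2OCc2cccc(F)c2)Oc2ccccc21`, has not yet been measured. It differs from compound 3 by 3-fluorophenyl in place of 2-methylprop-1-en-1-yl on a saturated chain carbon bound to an oxygen on an aromatic ring.

Among the measured compounds shown here, two measured steps bear on this change. The step of a 1.3-fold higher number from compound 1 to compound 3 (0.13 log units; within the scatter) covers the same place with a 4-fluorophenyl group removed; the step of a 1.2-fold higher number from compound 2 to compound 3 (0.08 log units; within the scatter) covers it with a 4-isopropylphenyl group removed. Both are within the scatter, and the series shows no step beyond it. An aryl group entering at this position, as in compound 1 with 25500 nM, has so far left the number where it was.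

Compound 4 is therefore expected to show a step of a 1.3-fold lower number from compound 3 to compound 4 (0.10 log units; within the scatter), no more than the scatter. The estimate for compound 4 is 27000 nM, with a range from 13000 nM to 55000 nM.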

Compound 4, half-maximal inhibitory concentration: 13200 nM
Compound 4: middle estimate off by 2.0-fold (0.31 log units), on the high side; the range from low to high includes it.
By their numbers in this assay, from the lowest: compounds 4, 1, 2 and 3 (each within the scatter of the next, the first and the last beyond it).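

In this assay the place on a saturated chain carbon bound to an oxygen on an aromatic ring now shows steps beyond the scatter: 3-fluorophenyl in place of 2-methylprop-1-en-1-yl gives a 2.6-fold lower number from compound 3 to compound 4 (0.41 log units; beyond the scatter) and 3-fluorophenyl in place of 4-isopropylphenyl gives a 2.2-fold lower number from compound 2 to compound 4 (0.34 log units; beyond the scatter) with both steps modest. Against 4-fluorophenyl, the same group gives a 1.9-fold lower number from compound 1 to compound 4 (0.29 log units; within the scatter) and that step stays within the scatter, so compound 1 and compound 4 cannot be ordered, and moving the fluoro group from 4-fluorophenyl to 3-fluorophenyl has no readable result. Compound 1 also stays within the scatter of compound 3, so the three steps do not divide the series into two clear groups, and an aryl group as such does not account for the separation.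

Going by these compounds, whether an amine, a carboxylic acid or a longer chain in place of 3-fluorobenzyl would move the number further remains open. On these data alone, it is also open whether 3-chlorophenyl or 3-methoxyphenyl would match 3-fluorophenyl at this place.

Nothing measured here explains these steps.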